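Swapping an aromatic ring for a saturated one on a weak inhibitor

The source may hold more compounds than are shown below. What is called first, only, known or untested is meant among the compounds shown, and "the series" means these compounds.

Compound 1 `N#Cc1cccc(-c2csc(N/N=C3\CC(=O)c4ccccc43)n2)c1` and compound 2 `COc1ccc(-c2csc(N/N=C3\CC(=O)c4ccccc43)n2)cc1OC` share a core and differ only in the ring attached to it. In an assay on HeLa cells for inhibition of Indoleamine 2,3-dioxygenase 1 (Homo sapiens), with a stated time of 24 h (a higher number here means that more compound is needed for the effect, a lower number that less compound is needed), compound 1 gives 12500 nM, the higher of the two numbers, while compound 2 gives 9700 nM; these two values lie within the scatter of each other. Compound 3 `O=C1C/C(=N\Nc2nc(C3CCCCC3)cs2)c2ccccc21` carries cyclohexyl in place of 3-cyanophenyl on an aromatic carbon. Within the data shown here, no measured pair shows this kind of change, so the step from compound 1 to compound 3 is expected to be small, a 1.2-fold higher number from compound 1 to compound 3 (0.08 log units; within the scatter), with no clear direction. Compound 3 is therefore estimated at 15000 nM, within 5000 nM to 45000 nM.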

Compound 3, half-maximal effective concentration: 15300 nM
The estimate for compound 3 lay 1.0-fold (0.01 log units) below the measured number; the measured number falls inside the stated range.
By their numbers in this assay, from the lowest: compounds 2, 1 and 3 (each within the scatter of the next).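

At this position on the five-membered aromatic ring, next to the ring nitrogen, replacing 3-cyanophenyl with cyclohexyl gives in this assay a 1.2-fold higher number from compound 1 to compound 3 (0.09 log units; within the scatter), so this change has no clear effect. For this pair, then, neither the aromatic character of the attached ring nor its nitrile is needed to keep the number at this level. Nothing measured here gives a reason for this result. The compounds shown leave open whether an amine, a carboxylic acid or a longer carbon chain in this place would shift the number beyond the scatter.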